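Three sulfonamides at the limit, and a fourth

The source may hold more compounds than are shown below. What is called first, only, known or untested is meant among the compounds shown, and "the series" means these compounds.

Three sulfonamides were tested in an assay on cells for inhibition of HSP60/HSP10 (Homo sapiens), with a stated time of 60 min; on this read-out higher numbers stand for weaker inhibition and lower numbers for stronger inhibition. Compound 1 `O=S(=O)(Nc1ccc2oc(-c3ccccc3)nc2c1)c1cccc(C(F)(F)F)c1` gave only a limit, > 100000 nM. Compound 2 `COc1cccc(S(=O)(=O)Nc2ccc3oc(-c4ccccc4)nc3c2)c1` likewise gave only a limit, > 100000 nM. Compound 3 `O=S(=O)(Nc1ccc(-c2nc3ccccc3o2)cc1)c1ccccc1F` also returned a limit, > 100000 nM. Within the data shown here, the single step among them, a step that the two limits leave unreadable from compound 1 to compound 2, cannot be read because of the limit of > 100000 nM in this assay, at which 3 of the 3 values shown sit. Compound 2 therefore stands at the limit of this assay, with no number beneath it. Compound 4 `O=S(=O)(Nc1ccc2oc(-c3ccccc3)nc2c1)c1ccc(O)cc1` differs from compound 2 by 4-hydroxyphenyl in place of 3-methoxyphenyl on a sulfonyl sulfur. Among the measured compounds shown here, no measured step bears on this change, and the only step recorded is itself unreadable. Nothing among compounds 1, 2 and 3 points to a gain in this assay, since all three sit at the limit. Compound 4 is therefore expected to stay at the limit as well, with a number no higher from compound 2 to compound 4 (the limit leaves the size open) meaning no readable movement. The estimate for compound 4 is 100000 nM, expected to fall between 30000 nM and 300000 nM.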

Compound 4, half-maximal inhibitory concentration: 88000 nM
The estimate for compound 4 lay 1.1-fold (0.06 log units) above the measured number; the measured number falls inside the stated range.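

In this assay, among these compounds, compound 4 gives 88000 nM, the only number among the four compounds that is not a limit, so a group on this sulfonyl sulfur can bring the read-out to a measured value. The change to 4-hydroxyphenyl in place of 3-methoxyphenyl gives an at least 1.1-fold lower number from compound 2 to compound 4 (0.05 log units; that floor lies within the scatter), and that floor alone does not establish a real difference between the two groups. The full size of this step remains unknown, and the step from compound 1 to compound 2 cannot be read, because both rest on a limit: the limit of > 100000 nM in this assay, at which 3 of the 4 values shown sit.

The compounds shown leave open whether the hydroxy group itself or its place on the ring sets this number. They also leave open what an amine or a carboxylic acid on that phenyl ring would give.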